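Adding an azetidine ring to a pyridylmethyl triazole amine

The compounds below may be only part of what the source reports. "The series", "measured", "known", "first", "only" and "open" are said of these compounds alone.

Measured so far:
compound 1, `Clc1cccc(-n2ncnc2Nc2ccccc2)c1Cl`: 3890 nM
compound 2, `Clc1cccc(-n2ncnc2NCc2cccnc2)c1Cl`: 1320 nM

In a functional assay for antagonist activity at P2X purinoceptor 7 (Rattus norvegicus), read by FLIPR and calcium flux (a lower number here means a stronger inhibitor, a higher number a weaker inhibitor), compound 1 gives 3890 nM, while compound 2 gives 1320 nM. For the measured compounds named here, the only measured step is a 2.9-fold lower number from compound 1 to compound 2 (0.47 log units; beyond the scatter). Compound 2 therefore stands at the lowest of the two numbers, with compound 1 the nearest neighbour at a higher value.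

Compound 3, `Clc1cccc(-n2ncnc2NCc2cccnc2N2CCC2)c1Cl`, differs from compound 2 in one place: azetidin-1-yl in place of hydrogen on an aromatic carbon. Going by the values given here, no measured step touches this part of the molecule, since the single step from compound 1 to compound 2 changed the group on the triazole nitrogen, not the pyridine ring. The expectation for compound 3 therefore rests on compound 2 alone, with a wide range: the estimated step is a 1.5-fold lower number from compound 2 to compound 3 (0.17 log units; within the scatter), a small shift that may not exceed the scatter. Compound 3 is expected to give about 900 nM, between 250 nM and 3500 nM.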

Compound 3, half-maximal inhibitory concentration: 25.7 nM
For compound 3 the middle estimate is 35-fold (1.54 log units) above the measured one; the whole stated range lies above it.
By their numbers in this assay, from the lowest: compound 3; then compound 2; then compound 1.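

In this assay, putting azetidin-1-yl on the aromatic carbon next to the ring nitrogen gives a 51-fold lower number from compound 2 to compound 3 (1.71 log units; beyond the scatter), a far larger change than a 2.9-fold lower number from compound 1 to compound 2 (0.47 log units; beyond the scatter). This shows that the pyridine ring, left unchanged between the two earlier compounds, holds a position where one substitution can strongly alter the reading, and here that substitution replaces a lone hydrogen with a group of only 4 heavy atoms. No available evidence explains why this change has so large an effect.

The compounds shown leave open whether the effect requires the four-membered ring or would also appear with a dimethylamino group, a pyrrolidin-1-yl ring or a methoxy group at the same place. They also leave open whether the azetidine ring itself can carry further groups, such as a hydroxyl or a fluorine atom.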